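Sulfonamide-to-amide exchange on the isothiocyanate linker

The source may report more compounds than this note shows. Statements on the series, on what has been measured and on what is new or still open speak of the compounds shown alone.

Measured in a functional assay on NCI-H1299 cells (Homo sapiens) for inhibition, read by CCK-8 assay, with a stated time of 72 h, tested at 1 uM; a lower number here means a weaker effect, a higher number a stronger effect of the compound at the concentration tested:
compound 1, `CN(C)C(=O)c1cc2cnc(Nc3ccc(S(=O)(=O)NCCCCCN=C=S)cc3)nc2n1C1CCCC1`: 52.1%
compound 2, `CN(C)C(=O)c1cc2cnc(Nc3ccc(S(=O)(=O)NCCCCCCN=C=S)cc3)nc2n1C1CCCC1`: 42.4%

Compound 1 gives the higher of the two numbers, though the step of a number 9.7 percentage points lower from compound 1 to compound 2 (within the scatter) lies within the scatter. Compound 3, `CN(C)C(=O)c1cc2cnc(Nc3ccc(NC(=O)CCCCN=C=S)cc3)nc2n1C1CCCC1`, is not yet measured. It differs from compound 1 by a group of 10 heavy atoms (6 carbon, 2 nitrogen, 1 oxygen, 1 sulfur; no ring) in place of a group of 12 heavy atoms (6 carbon, 2 nitrogen, 2 oxygen, 2 sulfur; no ring), on an aromatic carbon. Among the measured compounds shown here, the only measured step, lengthening the saturated chain by one carbon, does not touch the sulfonamide itself, so no measured step bears directly on this exchange. Compound 3 is therefore expected near compound 1, with an estimated step of a number 4.1 percentage points lower from compound 1 to compound 3 (within the scatter) not beyond the scatter. Compound 3 is estimated at 48%, between 28% and 68%.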

Compound 3, a percentage reported as inhibition, at one concentration (the size of the read-out at that concentration, not a potency): 58.6%
Estimate against measurement, compound 3: 10.6 percentage points below; low and high end bracket the measured number.
By their numbers in this assay, from the lowest: compounds 2, 1 and 3 (each within the scatter of the next, the first and the last beyond it).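

Among the compounds shown here, the first measured change on this aromatic carbon, para to a large group, is the exchange of the sulfonamide linker for the amide linker. In this assay it gives a number 6.5 percentage points higher from compound 1 to compound 3 (within the scatter), so the two linkers are not told apart at this concentration. The sulfonamide is therefore not required for a read-out of this size within this pair, and no evidence bears on the result. Still open, from the compounds shown here alone, is how a longer chain reads on the amide linker. Also open, going by these compounds, is whether an acrylamide in place of the isothiocyanate gives a similar read-out.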